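Trimming an isopropyl amide to ethyl on compound 2

The compounds below may be only part of what the source reports. "The series", "measured", "known", "first", "only" and "open" are said of these compounds alone.

Of the compounds shown here, three have been measured in an assay for inhibition of serine/threonine-protein kinase PLK2 (Homo sapiens), read by FRET and Z'-LYTE, with a stated time of 1 h; on this read-out lower numbers stand for stronger inhibition and higher numbers for weaker inhibition. Compound 1 `CC[C@@H]1C(=O)N(C)c2cnc(-n3ccc4cc(C(N)=O)ccc43)nc2N1C1CCCC1` gives 28.5 nM, compound 3 `CC[C@@H]1C(=O)N(C)c2cnc(Nc3ccc(S(=O)(=O)Nc4ccccc4)cc3)nc2N1C1CCCC1` gives 54.4 nM, and compound 2 `CCC1C(=O)N(C)c2cnc(-n3ccc4cc(C(=O)NC(C)C)ccc43)nc2N1c1ccn(C)n1` gives 125 nM, the highest of the three numbers, beyond the scatter from both of the others. Compound 4 `CCNC(=O)c1ccc2c(ccn2-c2ncc3c(n2)N(c2ccn(C)n2)C(CC)C(=O)N3C)c1` has not yet been measured. It differs from compound 2 in one place: hydrogen in place of methyl on a saturated chain carbon bound to an amide-type nitrogen and a saturated chain carbon. Among the compounds with values here, no measured pair shows this exact change, so only its small size guides the expectation. The step from compound 2 to compound 4 is expected to stay near or within the scatter, a 1.3-fold lower number from compound 2 to compound 4 (0.10 log units; within the scatter), tending if anything toward a slightly lower number. Compound 4 is therefore estimated at 100 nM, in a range from 40 nM to 250 nM.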

Compound 4, half-maximal inhibitory concentration: 243 nM
Estimate against measurement, compound 4: 2.4-fold (0.39 log units) below, within the range that was stated.
By their numbers in this assay, from the lowest: compounds 1 and 3 (each within the scatter of the next); then compounds 2 and 4 (each within the scatter of the next).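

Within the data shown here, this pair is the first in the set to differ in one place only: isopropylcarbamoyl to ethylcarbamoyl gives a 1.9-fold higher number from compound 2 to compound 4 (0.29 log units; within the scatter) in this assay. On this evidence, losing that one methyl cannot be told apart from repeat-measurement noise, so this single pair shows no clear effect of the change. Nothing available here offers an explanation for the step. Still open, from the compounds shown here alone, is how a longer chain such as butyl, or a carboxylic acid, would read in this place. One pair also cannot show whether the same change behaves alike on other cores.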